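Swapping the aryl group on the imine of compound 2

This account rests on a few compounds, and the source may have more. Where it says the series, first, only, none or still open, it means among the compounds named here.

Measured compounds:
- compound 1 `CCOc1cccc(/C=N/c2c(C)n(C)n(-c3ccccc3)c2=O)c1` gives in a functional assay on HCT-116 cells (Homo sapiens) for cytotoxicity, read by MTT assay, with a stated time of 72 h (a higher number here means a weaker inhibitor, a lower number a stronger inhibitor), a value of 933000000 nM
- compound 2 `COc1cccc(/C=N/c2c(C)n(C)n(-c3ccccc3)c2=O)c1` gives in this assay a value of 933000000 nM
- compound 3 `COc1cccc(/C=N/c2c(C)n(C)n(-c3ccccc3)c2=O)c1O` gives in this assay a value of 89100000 nM

Compound 2 sits level with compound 1 at the highest number of the three, and the step from compound 1 to compound 2, no change at the digits printed from compound 1 to compound 2 (within the scatter), stays within the scatter. Among the compounds with values here, the only step beyond the scatter runs to compound 3: a 10-fold lower number from compound 2 to compound 3 (1.02 log units; beyond the scatter), a large drop in the number.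

Compound 4 `Cc1c(/N=C/c2ccc(O)cc2)c(=O)n(-c2ccccc2)n1C` is not yet measured. Relative to compound 2 the change is 4-hydroxyphenyl in place of 3-methoxyphenyl on a carbon with a double bond to nitrogen. Within the data shown here, two measured steps bear on this. The step from compound 1 to compound 2 shows that removing a methyl from the oxygen substituent changes nothing beyond the scatter, so losing the methoxy by itself is not expected to move the number. The step from compound 2 to compound 3 shows that bringing in a hydroxy on the aryl ring lowers the number strongly. Compound 4 carries a hydroxy and no methoxy, though at a different ring position from compound 3, so a lower number than compound 2 is expected, probably of a size near a 6.2-fold lower number from compound 2 to compound 4 (0.79 log units; beyond the scatter), with real uncertainty. The expected value for compound 4 in this assay is 150000000 nM, within a range from 30000000 nM to 933000000 nM.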

Compound 4, half-maximal inhibitory concentration: 646000000 nM
Compound 4: the middle estimate sits 4.3-fold (0.63 log units) below what was measured, within the range that was stated.
By their numbers in this assay, from the lowest: compound 3; then compounds 4, 1 and 2 (each within the scatter of the next).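

In this assay, putting 4-hydroxyphenyl in place of 3-methoxyphenyl on the carbon with a double bond to nitrogen gives only a small step (a 1.4-fold lower number from compound 2 to compound 4 (0.16 log units; within the scatter)), unlike the large one seen when a hydroxy joins the methoxy (a 10-fold lower number from compound 2 to compound 3 (1.02 log units; beyond the scatter)). The earlier compounds shown here might have suggested that any hydroxy on this aryl group lowers the number, but compound 4, which has a hydroxy and no methoxy, gives 646000000 nM, whereas compound 3, which carries both groups, gives 89100000 nM. Nothing measured here explains why these two hydroxy-bearing compounds read so differently.

The compounds shown leave open whether the lower number of compound 3 depends on where its hydroxy sits on the ring, on the methoxy being present alongside it, or on both. Also open, going by these compounds, is how this assay would respond to an amine or a carboxylic acid in place of the hydroxy of compound 4.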